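The compounds below may be only part of what the source reports. "The series", "measured", "known", "first", "only" and "open" are said of these compounds alone.

Of the compounds shown here, three sharing one core have been tested in a functional assay on A549 cells (Homo sapiens) for antiproliferative activity, read by MTT assay, with a stated time of 48 h (on this read-out lower numbers stand for stronger inhibition and higher numbers for weaker inhibition), so far. Compound 1 `COc1ccc(N(C)c2ccnc(Cl)n2)cc1` reads 611 nM and compound 2 `COc1ccc(N(C)c2ccnc(Cl)n2)cc1F` reads 651 nM while compound 3 `COc1ccc(N(C)c2ccnc(Cl)n2)cc1[N+](=O)[O-]` reads 3780 nM as the highest number of the three. Compound 3 is thus the weakest inhibitor of this small set. The data show a 6.2-fold higher number from compound 1 to compound 3 (0.79 log units; beyond the scatter) and a 5.8-fold higher number from compound 2 to compound 3 (0.76 log units; beyond the scatter) whereas fluoro in place of hydrogen gave a 1.1-fold higher number from compound 1 to compound 2 (0.03 log units; within the scatter) and so no real change.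

Compound 4 `COc1ccc(N(C)c2ccnc(Cl)n2)cc1O` has not been measured yet. It carries hydroxy in place of nitro on an aromatic carbon, ortho to a methoxy group. Going by the values given here, no other hydroxy compound has been measured, so the closest guides are the two nitro steps at this same carbon, both modest but clear. Taking the nitro away is therefore expected to undo much of a 5.8-fold higher number from compound 2 to compound 3 (0.76 log units; beyond the scatter) and bring the number back toward the two values without nitro, though perhaps not all the way. The expected change is a 4.2-fold lower number from compound 3 to compound 4 (0.62 log units; beyond the scatter) as an estimate. Compound 4 is estimated in this assay at 900 nM with a likely range from 350 nM to 2400 nM for now.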

Compound 4, half-maximal inhibitory concentration: 381 nM
Compound 4: the middle estimate sits 2.4-fold (0.37 log units) above what was measured; measured number inside the range.
By their numbers in this assay, from the lowest: compounds 4, 1 and 2 (each within the scatter of the next); then compound 3.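

In this assay, the exchange of nitro for hydroxy on this aromatic carbon, ortho to a methoxy group, gives a 9.9-fold lower number from compound 3 to compound 4 (1.00 log units; beyond the scatter), so the high number seen with nitro does not carry over to a group that enters with a hydrogen-bond donor. Hydroxy also cannot be told apart from the two smaller groups at this carbon: a 1.7-fold lower number from compound 2 to compound 4 (0.23 log units; within the scatter) and a 1.6-fold lower number from compound 1 to compound 4 (0.21 log units; within the scatter) are both steps that stay within the scatter, which leaves nitro as the only one of the four groups seen here that stands apart from the rest. Nothing available explains why nitro differs in this way.

Going by these compounds, it remains open whether an amine, a carboxylic acid or a longer chain such as ethoxy on this same carbon would read like hydrogen, fluoro and hydroxy or would move toward nitro. It is also open whether the same pattern would hold if the methoxy group were replaced, since every compound shown here keeps it.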